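The source may report more compounds than this note shows. Statements on the series, on what has been measured and on what is new or still open speak of the compounds shown alone.

Values in a functional assay on WRL68 cells (Homo sapiens) for cytotoxicity, read by MTT assay, with a stated time of 4 h; a higher number here means a weaker inhibitor, a lower number a stronger inhibitor:
- compound 1 `COC(=O)C1=CO[C@@H](O[C@@H]2O[C@H](CO)[C@@H](OC(C)=O)[C@H](OC(C)=O)[C@H]2OC(C)=O)[C@@H]2[C@@H](C)[C@@H](OC(C)=O)C[C@H]12` gives "not active" (no number reported)
- compound 2 `CCCCCCCCCCCCCC(=O)OC[C@H]1O[C@@H](O[C@@H]2OC=C(C(=O)OC)[C@H]3C[C@H](OC(C)=O)[C@H](C)[C@@H]23)[C@H](OC(C)=O)[C@@H](OC(C)=O)[C@@H]1OC(C)=O` gives 58.5 ug/mL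
- compound 3 `CCCCCCCCCCCCCCCC(=O)OC[C@H]1O[C@@H](O[C@@H]2OC=C(C(=O)OC)[C@H]3C[C@H](OC(C)=O)[C@H](C)[C@@H]23)[C@H](OC(C)=O)[C@@H](OC(C)=O)[C@@H]1OC(C)=O` gives "not active" (no number reported)

Compound 1 has no number in this assay and stands with compound 3 as an entry without one. Only compound 2 gives a number. Compound 4 `COC(=O)C1=CO[C@@H](O[C@@H]2O[C@H](COC(=O)C=C(C)C)[C@@H](OC(C)=O)[C@H](OC(C)=O)[C@H]2OC(C)=O)[C@@H]2[C@@H](C)[C@@H](OC(C)=O)C[C@H]12` is not yet measured. Its change from compound 1 is (2-methylprop-1-en-1-yl)carbonyl in place of hydrogen on an oxygen on a saturated carbon, with (2-methylprop-1-en-1-yl)carbonyl in place of hydrogen on an oxygen on a saturated carbon. Compound 2 and compound 3 also carry an ester chain on that oxygen, yet their outcomes differ, so the direction is not settled. A step towards a measurable but weak value is expected, though a not-active result remains quite possible. For compound 4 the expected value is 60 ug/mL, with an estimated range of 30 ug/mL to 120 ug/mL.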

Compound 4, half-maximal inhibitory concentration: 1.2 ug/mL
Compound 4: the middle estimate sits 50-fold (1.70 log units) above what was measured; the measured number lies below the stated range.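

Within the data shown here, compound 1 has no number in this assay, and no step to compound 4 can be read. The compounds shown leave open how much the (2-methylprop-1-en-1-yl)carbonyl group contributes to the result for compound 4, and no measured evidence bears on this.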